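The compounds below may be only part of what the source reports. "The series", "measured", "known", "first", "only" and "open" are said of these compounds alone.

Working notes on the series, all numbers from a functional assay on the whole organism for inhibition, with Mus musculus as the target, in the writhing test, with a stated time of 15 min, at a dose of 10 mg/kg; a higher number here means more inhibition at the dose given (going by the name of the read-out), a lower number less inhibition.

Compound 1, `COc1ccc(C2CC(C3C(=O)c4ccccc4C3=O)=NC(=O)N2)cc1`: compound 1 gives 31%.
Compound 2, `O=C1N=C(C2C(=O)c3ccccc3C2=O)CC(c2ccc(Cl)cc2)N1`: compound 2 gives 44%.
Compound 3, `O=C1N=C(C2C(=O)c3ccccc3C2=O)CC(c2ccccc2O)N1`: compound 3 gives 37%.

Compound 3 sits second highest of the three numbers, but both of its neighbours are within the scatter: one gap is a number 6 percentage points higher from compound 1 to compound 3 (within the scatter) and the other gap is a number 7 percentage points lower from compound 2 to compound 3 (within the scatter). For the measured compounds named here, the only step beyond the scatter in the set is a number 13 percentage points higher from compound 1 to compound 2 (beyond the scatter), a change on the aromatic carbon rather than on the saturated ring carbon.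

Compound 4, `O=C1N=C(C2C(=O)c3ccccc3C2=O)CC(c2ccco2)N1`, is not yet measured. Its change from compound 3 is furan-2-yl in place of 2-hydroxyphenyl on a saturated ring carbon.

Going by the values given here, the steps that bear on this change are the two exchanges of the aryl group on the saturated ring carbon, a number 6 percentage points higher from compound 1 to compound 3 (within the scatter) and a number 7 percentage points lower from compound 2 to compound 3 (within the scatter), both within the scatter. So far, swapping this aryl group has not moved the read-out beyond the scatter, while no furan-2-yl has been measured here, so the expectation rests on three compounds only. The expected step is no change at the digits printed from compound 3 to compound 4 (within the scatter), i.e. no change beyond the scatter.

Compound 4 is therefore estimated at 37%, with a range from 24% to 50%.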

Compound 4, a percentage reported as inhibition, in the whole organism at one dose (the size of the read-out at that dose, not a potency): 25%
Compound 4: the middle estimate sits 12 percentage points above what was measured; measured number inside the range.
By their numbers in this assay, from the lowest: compounds 4, 1, 3 and 2 (each within the scatter of the next, the first and the last beyond it).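

In this assay, the exchange at the saturated ring carbon now moves the read-out beyond the scatter, with a number 12 percentage points lower from compound 3 to compound 4 (beyond the scatter) and a number 19 percentage points lower from compound 2 to compound 4 (beyond the scatter), whereas the earlier exchanges of the whole group at this place stayed within it. The pattern is not uniform: compound 1, with 4-methoxyphenyl, goes against it, since the same entry of furan-2-yl gives a number 6 percentage points lower from compound 1 to compound 4 (within the scatter). The step from compound 2 removes 4-chlorophenyl rather than 2-hydroxyphenyl, so loss of the hydroxy group alone does not describe both steps beyond the scatter. No measurement at hand accounts for these steps.

The compounds shown do not separate the change from a six-membered aromatic ring of carbon only to a five-membered aromatic ring from the presence of the ring oxygen, a question that thiophen-2-yl and unsubstituted phenyl at the same carbon could address. Also open, as far as these compounds go, is whether a non-aromatic group at this carbon, such as a cyclohexyl ring or a short alkyl chain, would fit with the aryl groups or with furan-2-yl in this read-out.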